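One flipped stereocentre: from compound 2 to compound 4

The compounds below may be only part of what the source reports. "The series", "measured", "known", "first", "only" and "open" are said of these compounds alone.

Measured in an ADME assay on KB cells (Homo sapiens) for cytotoxicity, with a stated time of 48 h; a higher number here means a weaker inhibitor, a lower number a stronger inhibitor:
- compound 1 `C=C1[C@H](C)CCC[C@]1(C)CC/C(C)=C/CC1=C(O)C(=O)C=C(N[C@@H](C(=O)O)C(C)C)C1=O`: 6.2 ug/mL
- compound 2 `CC1=CCC[C@](C)(CC/C(C)=C/CC2=C(O)C(=O)C=C(N[C@@H](C(=O)O)C(C)C)C2=O)[C@@H]1C`: > 10 ug/mL
- compound 3 `C=C1[C@H](C)CCC[C@]1(C)CC/C(C)=C/CC1=C(O)C(=O)C=C(NCC(=O)O)C1=O`: 4 ug/mL

Compound 2 has no number, only a limit, and it stands at the limit of > 10 ug/mL in this assay, at which 1 of the 3 values shown sits. The next compound, compound 4 `CC1=CCC[C@](C)(CC/C(C)=C/CC2=C(O)C(=O)C=C(N[C@H](C(=O)O)C(C)C)C2=O)[C@@H]1C`, is not yet measured in this assay. Its difference from compound 2 is small: the two compounds have the same atoms and bonds and differ only in configuration as drawn: 1 of 4 stereo elements differ; a stereocentre at a saturated chain carbon is drawn R in compound 2 and S in compound 4. The stereocentre in question is a saturated chain carbon.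

Among the measured compounds shown here, no measured pair shows what such a change in configuration does, so the evidence is indirect. Replacing isopropyl with hydrogen on a saturated chain carbon bound to an amine nitrogen and a carbonyl carbon gave a 1.6-fold lower number from compound 1 to compound 3 (0.19 log units; within the scatter). The other measured change gave an at least 1.6-fold higher number from compound 1 to compound 2 (0.20 log units; that floor lies within the scatter). Neither step goes beyond the scatter, so no step beyond the scatter is expected here, and compound 4 may also return only a limit. The expected change is a step that the limit leaves unreadable from compound 2 to compound 4 in this estimate. Compound 4 is estimated at 11 ug/mL, with an expected range from 6 ug/mL to 20 ug/mL.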

Compound 4, half-maximal inhibitory concentration: > 10 ug/mL
Compound 4: only a limit was reported (the forecaster's own chance of this, stated with the estimate: 60%); the middle value lies beyond the limit too.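

No step can be read between compound 2 and compound 4, because both are reported only as a limit: the limit of > 10 ug/mL in this assay, at which 2 of the 4 values shown sit. The compounds shown leave open whether the stereocentre drawn R in compound 2 and S in compound 4 changes the number in this assay at all.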